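The source may hold more compounds than are shown below. What is called first, only, known or untested is meant among the compounds shown, and "the series" means these compounds.

Measured compounds and their values:

compound 1 `CN(C)c1ccc(C2CC(c3ccccc3)=NN2C2=NC(=O)/C(=C3\C(=O)Nc4ccc(Br)cc43)S2)cc1` — 210 nM
compound 2 `COc1ccc(-c2cc(-c3ccc(Cl)cc3)n(C3C(=O)Nc4ccc(Br)cc43)n2)cc1` — 5480 nM
compound 3 `COc1ccc(-c2cc(-c3ccc(Cl)cc3)n(C3C(=O)Nc4ccc(Cl)cc43)n2)cc1` — 3940 nM

In a functional assay on cells (Cancer cell lines, Homo sapiens) for cytotoxicity, read by sulforhodamine B assay, with a stated time of 48 h (on this read-out lower numbers stand for stronger inhibition of growth and higher numbers for weaker inhibition of growth), compound 2 gives 5480 nM, the highest of the three numbers. Its nearest neighbour is compound 3, which gives 3940 nM; the step of a 1.4-fold lower number from compound 2 to compound 3 (0.14 log units; within the scatter) lies within the scatter. Among the measured compounds shown here, compound 1, built on a different core, gives 210 nM, a number that lies far below that of compound 2 and beyond the scatter, but no single-point step connects these two.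

Compound 4 `O=C1Nc2ccc(Br)cc2C1n1nc(-c2ccc3ccccc3c2)cc1-c1ccc(Cl)cc1` differs from compound 2 in one place: naphthalen-2-yl in place of 4-methoxyphenyl on an aromatic carbon. Of the measured steps, only a 1.4-fold lower number from compound 2 to compound 3 (0.14 log units; within the scatter) is available, and it concerns a halogen exchange elsewhere on the shared core, not the group that is replaced here. For the measured compounds named here, no measured pair shows what exchanging the 4-methoxyphenyl for naphthalen-2-yl does in this assay. With nothing to point in either direction, the expectation for this change is a step of no size beyond the scatter, which is the estimate behind a 1.1-fold lower number from compound 2 to compound 4 (0.04 log units; within the scatter). Compound 4 is therefore expected to give about 5000 nM in this assay, with an estimated range from 1500 nM to 16000 nM.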

Compound 4, concentration for 50% growth inhibition: 3180 nM
Compound 4: middle estimate off by 1.6-fold (0.20 log units), on the high side, and the stated range covers the measured number.
By their numbers in this assay, from the lowest: compound 1; then compounds 4, 3 and 2 (each within the scatter of the next).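

In this assay, among the compounds shown here, the exchange of 4-methoxyphenyl for naphthalen-2-yl gives a 1.7-fold lower number from compound 2 to compound 4 (0.24 log units; within the scatter), the first reading at this aromatic carbon of the five-membered aromatic ring with 2 nitrogen. The earlier step among the compounds of this series concerned only chloro in place of bromo, elsewhere on the shared core, and so said nothing about this position. The new step shows that here a group with 2 six-membered aromatic rings of carbon only can stand in place of one with a single such ring and 1 hydrogen-bond acceptor, without a shift beyond the scatter.

Still open, as far as these compounds go, is whether an amine, a carboxylic acid or a small methyl group on this aromatic carbon would move the number beyond the scatter, and whether naphthalen-2-yl would behave in the same way on compound 3, which carries chloro in place of bromo. No evidence at hand speaks to why this exchange leaves the number within the scatter.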